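From hydroxy to amino in an antiproliferative series

A few compounds are considered here, and "the series" means these few. Any claim that something is new, unique, unknown or untested is made for them only; others in the source may bear on it.

Compound 1 `C=C(c1cc(OC)c(OC)c(OC)c1)c1ccc(OC)cc1NC(=O)CO` gives 30 nM
Compound 2 `C=C(c1ccc2c(c1)C=CC(C)(C)O2)c1ccc(OC)cc1NC(=O)CN` gives 160 nM

In a functional assay on HeLa cells (Homo sapiens) for antiproliferative activity, read by MTT assay, with a stated time of 48 h (on this read-out higher numbers stand for weaker inhibition and lower numbers for stronger inhibition), compound 1 gives 30 nM and holds the lower of the two measured numbers, while compound 2 stands at 160 nM with a gap beyond the usual scatter.

Compound 3 `C=C(c1cc(OC)c(OC)c(OC)c1)c1ccc(OC)cc1NC(=O)CN` is compound 1 with amino in place of hydroxy on a saturated chain carbon bound to a carbonyl carbon and no other change. Within the data shown here, no measured pair shows this change alone. Compound 2 carries (aminomethyl)carbonyl as well and reads 160 nM on a different core, so it offers only a weak hint towards a higher number. The swap is small, so no change beyond the scatter is expected, with a slightly higher number the likelier direction. The expected size is a 1.3-fold higher number from compound 1 to compound 3 (0.12 log units; within the scatter) as an estimate. For compound 3 the estimated value is 40 nM with an expected range from 12 nM to 130 nM in this measurement.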

Compound 3, half-maximal inhibitory concentration: 70 nM
The estimate for compound 3 lay 1.8-fold (0.24 log units) below the measured number; the range from low to high includes it.
By their numbers in this assay, from the lowest: compound 1; then compound 3; then compound 2.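

In this assay, among these compounds, amino in place of hydroxy on a saturated chain carbon bound to a carbonyl carbon gives a 2.3-fold higher number from compound 1 to compound 3 (0.37 log units; beyond the scatter) with nothing else in the molecule changed, the first direct reading of this swap. The position therefore responds to the exchange of one oxygen for one nitrogen, even though the counts of hydrogen-bond donors and acceptors stay the same, and the step is modest in size. No measurement at hand explains the higher number.

Going by these compounds, it remains open whether a dimethylamino group, a carboxylic acid or a longer chain at this place would give a number closer to that of compound 1 or further from it. On these data alone, it is also open whether the same swap would give a step of similar size on the core of compound 2.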